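This account rests on a few compounds, and the source may have more. Where it says the series, first, only, none or still open, it means among the compounds named here.

Measured compounds:
- compound 1, `C=C1C(=O)O[C@@H]2CC(C)=C([C@@H](C)CCCOC(C)=O)[C@@H](OC(=O)CN3CCCC3)[C@H]12` — 20500 nM
- compound 2, `C=C1C(=O)O[C@@H]2CC(C)=C([C@@H](C)CCCOC(C)=O)[C@@H](OC(=O)COc3ccc([N+](=O)[O-])cc3[N+](=O)[O-])[C@H]12` — > 100000 nM

Compound 1 carries a shared lactone core with an ester side group, and in a functional assay on HCT-116 cells (Homo sapiens) for cytotoxicity, read by sulforhodamine B assay, with a stated time of 72 h (on this read-out higher numbers stand for weaker inhibition and lower numbers for stronger inhibition), compound 1 gives 20500 nM. Among the measured compounds shown here, that is the only full number recorded here; the other entry is a limit. For the measured compounds named here, compound 2 reaches only the limit of > 100000 nM in this assay, which means the assay reports no number for it, only that the value lies past its upper edge, as stated in the limit of > 100000 nM in this assay, at which 1 of the 2 values shown sits. Going by the values given here, compound 1 therefore stands as the one compound with a measured value, and the two values together place both compounds at the weak end of this assay.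

Compound 3, `C=C1C(=O)O[C@@H]2CC(C)=C([C@@H](C)CCCOC(C)=O)[C@@H](OC(=O)c3ccccc3)[C@H]12`, is not yet measured. It keeps the same core and ester linkage but changes the ester group: phenyl in place of (pyrrolidin-1-yl)methyl on a carbonyl carbon. Among the compounds with values here, with no measured step between compounds that differ in one place, there is nothing to set the size of this change against. The expected step from compound 1 to compound 3 is a 1.2-fold higher number from compound 1 to compound 3 (0.09 log units; within the scatter), within the ordinary scatter and without a clear direction. In this assay compound 3 is expected to give about 25000 nM, with a likely range from 8000 nM to 100000 nM.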

Compound 3, half-maximal inhibitory concentration: 10500 nM
For compound 3 the middle estimate is 2.4-fold (0.38 log units) above the measured one; the measured number falls inside the stated range.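

In this assay, among the compounds shown here, phenyl in place of (pyrrolidin-1-yl)methyl on a carbonyl carbon gives a 2.0-fold lower number from compound 1 to compound 3 (0.29 log units; within the scatter), the first step that can be read at this position. The swap removes a non-aromatic ring with a nitrogen and brings in an aromatic ring of carbon only, yet the two numbers stay within the usual scatter of repeated measurements, so the nitrogen of compound 1 is not shown to matter for the cytotoxicity seen here. Compound 2, which carries a different group at this same place, gives a limit of the assay and not a number: the limit of > 100000 nM in this assay, at which 1 of the 3 values shown sits.

With a single readable step, the compounds shown do not tell whether any group on this carbonyl carbon can move the number beyond the scatter. How a benzyl group, a primary amine or a carboxylic acid would behave at this place in this assay remains open, as does the role of the acetate-bearing side chain, which is the same in all the compounds shown.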